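This account rests on a few compounds, and the source may have more. Where it says the series, first, only, none or still open, it means among the compounds named here.

Compound 1, `Sc1[nH]ccc2ncnc1-2`, gives 8 mg/kg in a functional assay on the whole organism (Pleural cavity) with Rattus norvegicus as the target; a lower number here means that less compound is needed, a higher number that more compound is needed for the effect.
Compound 2, `CSc1nccc2c1ncn2[C@H]1C[C@H](O)[C@@H](CO)O1`, gives only a limit in this assay, > 9 mg/kg.
Compound 3, `OC[C@H]1OC(n2cnc3c(SCc4ccccc4)nccc32)[C@H](O)[C@@H]1O`, gives 9 mg/kg in this assay.

Among the numbers that are not limits, compound 1 has the lower one, but compound 3 sits so close that the two lie within the usual scatter of each other, so no difference between them can be claimed. Only one limit appears here: the limit of > 9 mg/kg in this assay, at which 1 of the 3 values shown sits, and it belongs to compound 2, which says nothing about where that compound would actually fall.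

The next compound, compound 4, `CSc1[nH]ccc2ncnc1-2`, keeps the whole core of compound 1 and changes one thing: methyl in place of hydrogen on a sulfur. Within the data shown here, no measured pair here shows this exact change on this core, so the size of its effect is open. Without such a pair, the step is expected to be small, with no direction that can be read from the present numbers, and to stay within the scatter.

Compound 4 is therefore expected to give about 10 mg/kg, with a likely range from 4 mg/kg to 25 mg/kg. That estimate amounts to an expected step of a 1.3-fold higher number from compound 1 to compound 4 (0.10 log units; within the scatter).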

Compound 4, dose for half-maximal effect: 9 mg/kg
The estimate for compound 4 lay 1.1-fold (0.05 log units) above the measured number, within the range that was stated.
By their numbers in this assay, from the lowest: compounds 1, 3 and 4 (each within the scatter of the next).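

Among these compounds, a step of a 1.1-fold higher number from compound 1 to compound 4 (0.05 log units; within the scatter) in this assay gives the first direct reading of a single change on the shared core: methyl in place of hydrogen on a sulfur. On this core, the sulfur can therefore carry either hydrogen or methyl with no difference that can be claimed, so the free sulfanyl hydrogen does not appear to be needed for the effect in the whole animal. No measured property shown here accounts for this result.

Going by these compounds, whether this holds for anything larger remains open, since a single small step says little about a longer chain such as propyl on the same sulfur. A chain ending in an amine or a carboxylic acid at this place is also untested by the compounds shown.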